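The source may report more compounds than this note shows. Statements on the series, on what has been measured and on what is new or still open speak of the compounds shown alone.

Measured compounds in a functional assay on WI-38 VA13 cells (Homo sapiens) for cytotoxicity; on this read-out higher numbers stand for an effect only at larger amounts of compound and lower numbers for an effect already at smaller amounts:
- compound 1 `CNc1c(C(=O)c2ccccc2)sc2nc(-c3cccs3)ccc12`: 0.42 ug/mL
- compound 2 `COc1ccc(C(=O)c2sc3nc(-c4cccs4)ccc3c2N)cc1`: 0.77 ug/mL
- compound 3 `COc1ccc(OC)c(C(=O)c2sc3nc(-c4cccs4)ccc3c2N)c1`: 0.079 ug/mL

Compound 2 gives the highest number of the three. Its nearest neighbour is compound 1, whose number is lower but within the usual scatter, so the two are not distinguished here. Compound 3 is the furthest from compound 2, with a lower number beyond the scatter; among the three, compound 3 is the one that acts at smaller amounts.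

Compound 4 `Nc1c(C(=O)c2cccc(Br)c2)sc2nc(-c3cccs3)ccc12` has not yet been measured. It differs from compound 2 in one place: 3-bromophenyl in place of 4-methoxyphenyl on a carbonyl carbon. For the measured compounds named here, no measured pair shows a step of this kind, since compounds 1 and 3 differ from compound 2 in more than this one place, so the size of the step cannot be read off the series. Compound 1 and compound 2 carry different aryl groups on the carbonyl carbon yet lie within the scatter of each other, which gives no ground for expecting a large step. For compound 4 the expectation is a change no larger than the scatter, a 1.5-fold lower number from compound 2 to compound 4 (0.19 log units; within the scatter), and an estimated value of 0.5 ug/mL in this assay, with a range from 0.15 ug/mL to 1.6 ug/mL.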

Compound 4, half-maximal effective concentration: 0.5 ug/mL
Estimate against measurement, compound 4: no gap at the digits printed, and the stated range covers the measured number.
By their numbers in this assay, from the lowest: compound 3; then compounds 1, 4 and 2 (each within the scatter of the next).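

In this assay, for the compounds shown here, 3-bromophenyl in place of 4-methoxyphenyl on a carbonyl carbon gives a 1.5-fold lower number from compound 2 to compound 4 (0.19 log units; within the scatter) and is the first step that can be read at a single place. The position therefore accepts this exchange without a difference that can be told from the scatter, even though the group that enters is a bromine-bearing ring with no hydrogen-bond acceptor and the group that leaves has one. Nothing measured here explains this outcome or ties it to a property of either group.

From the compounds shown here alone, one pair cannot show whether other aryl groups at this place behave alike, and how a phenyl carrying an amine or a carboxylic acid would read stays open. Going by these compounds alone, no single-place step yet reaches compound 3 at 0.079 ug/mL so its value cannot be assigned to any one part of its structure.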